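The compounds below may be only part of what the source reports. "The series", "measured", "known", "first", "only" and "open" are said of these compounds alone.

- Compound 1 `COc1ccccc1NC(=S)N/N=C/c1ccc2ccccc2n1`: > 100000 nM (a limit of the assay, not a number)
- Compound 2 `S=C(N/N=C/c1ccc2ccccc2n1)Nc1cccc(Br)c1`: 78600 nM
- Compound 3 `S=C(N/N=C/c1ccc2ccccc2n1)Nc1ccc(Cl)cc1`: 87600 nM

These three compounds were tested in a functional assay on SGC-7901 cells (Homo sapiens) for antiproliferative activity, read by sulforhodamine B assay, with a stated time of 72 h (on this read-out lower numbers stand for stronger inhibition and higher numbers for weaker inhibition), and they differ only in the group on an amide-type nitrogen. Compound 1 gives only a limit. Compound 3 gives 87600 nM, which lies within the scatter of compound 2 at 78600 nM. Neither can be ranked above the other.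

The next compound is compound 4 `S=C(N/N=C/c1ccc2ccccc2n1)Nc1cccc(Cl)c1`, which has the same atoms as compound 3, joined differently: 3-chlorophenyl in place of 4-chlorophenyl on an amide-type nitrogen. It carries 3-chlorophenyl in place of 4-chlorophenyl on the amide-type nitrogen.

Among the measured compounds shown here, no measured step makes exactly this change. The closest is a 1.1-fold higher number from compound 2 to compound 3 (0.05 log units; within the scatter), which replaces 3-bromophenyl with 4-chlorophenyl and stays within the scatter. The other two steps, an at least 1.2-fold lower number from compound 1 to compound 2 (0.10 log units; that floor lies within the scatter) and an at least 1.1-fold lower number from compound 1 to compound 3 (0.05 log units; that floor lies within the scatter), start from a limit and give only floors within the scatter, so they say little about size. On this evidence, no step beyond the scatter is expected in this assay, and no direction can be favoured.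

The expected result is a 1.2-fold lower number from compound 3 to compound 4 (0.07 log units; within the scatter), a change within the scatter. Compound 4 is estimated at 75000 nM, with an expected range of 35000 nM to 100000 nM.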

Compound 4, half-maximal inhibitory concentration: 61300 nM
Estimate against measurement, compound 4: 1.2-fold (0.09 log units) above, and the stated range covers the measured number.
By their numbers in this assay, from the lowest: compounds 4, 2 and 3 (each within the scatter of the next). At a limit, above all of these: compound 1.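

Replacing 4-chlorophenyl with 3-chlorophenyl on the amide-type nitrogen keeps the same atoms and changes only how they are joined, and in this assay this gives a 1.4-fold lower number from compound 3 to compound 4 (0.16 log units; within the scatter), so the two chlorophenyl isomers cannot be told apart in this assay. Among the compounds shown here, the change of chloro in place of bromo on an aromatic carbon, with the rest of the structure unchanged, isolates the halogen for the first time; it gives a 1.3-fold lower number from compound 2 to compound 4 (0.11 log units; within the scatter), so this exchange cannot be resolved either. The step of an at least 1.6-fold lower number from compound 1 to compound 4 (0.21 log units; that floor lies within the scatter) is only a floor, since the entry for compound 1 is a limit of the assay and not a number: the limit of > 100000 nM in this assay, at which 1 of the 4 values shown sits.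

The compounds shown leave open whether any change on this phenyl ring can move the number beyond the scatter, as every step read here stays within it. Going by these compounds, an amine or a carboxylic acid on that ring, or a longer chain on the amide-type nitrogen in place of the phenyl ring, is not among them, so how such groups would behave in this assay remains unknown.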